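From methoxy to fluoro in a closely matched series

This account rests on a few compounds, and the source may have more. Where it says the series, first, only, none or still open, it means among the compounds named here.

Values measured so far in a functional assay on A-431 cells (Homo sapiens) for inhibition, read by MTT assay, with a stated time of 72 h (a higher number here means a weaker inhibitor, a lower number a stronger inhibitor), are:

Compound 1 `COc1ccc(-c2nnc(SCCCN3CCN(c4nc5ccccc5o4)CC3)o2)cc1` gives 52700 nM
Compound 2 `O=C(NCc1nnc(SCCCN2CCN(c3nc4ccccc4o3)CC2)o1)c1ccccc1` gives 36900 nM
Compound 3 `COc1ccc(-c2nnc(SCCCN3CCN(c4nc5ccccc5s4)CC3)o2)cc1` gives 56200 nM

Compound 3 sits level with the other two: all three numbers lie within the usual scatter of repeated measurements, so this assay does not separate them.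

Compound 4 `Fc1ccc(-c2nnc(SCCCN3CCN(c4nc5ccccc5s4)CC3)o2)cc1` keeps everything in compound 3 except one group. That group is the methoxy, which gives way to fluoro and so turns 4-methoxyphenyl into 4-fluorophenyl. For the measured compounds named here, the count of that difference reads fluoro in place of methoxy on an aromatic carbon and no measured pair makes this exact swap.

Two measured steps offer indirect guidance. The closer one is a 1.4-fold lower number from compound 1 to compound 2 (0.15 log units; within the scatter), where benzamidomethyl replaces the whole 4-methoxyphenyl. The other is a 1.1-fold higher number from compound 1 to compound 3 (0.03 log units; within the scatter), where 1,3-benzothiazol-2-yl replaces 1,3-benzoxazol-2-yl and which ties compound 3 to compound 1. Going by the values given here, neither step leaves the scatter, and no measured compound here carries fluoro. On that limited evidence, no step beyond the scatter is expected in this assay for this swap. The expected step is a 1.1-fold lower number from compound 3 to compound 4 (0.05 log units; within the scatter), which would lie within the scatter. For compound 4 the estimated value is 50000 nM, with an expected range from 25000 nM to 100000 nM.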

Compound 4, half-maximal inhibitory concentration: 67000 nM
For compound 4 the middle estimate is 1.3-fold (0.13 log units) below the measured one; the measured number falls inside the stated range.
By their numbers in this assay, from the lowest: compounds 2, 1, 3 and 4 (each within the scatter of the next).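

Going from methoxy to fluoro at this place, on an aromatic carbon para to a large group, gives in this assay a step of a 1.2-fold higher number from compound 3 to compound 4 (0.08 log units; within the scatter) and so does not separate the two compounds. The earlier step at this place replaced the whole 4-methoxyphenyl, whereas this one keeps the six-membered aromatic ring and exchanges only the group on it, with one oxygen hydrogen-bond acceptor leaving and a single fluorine entering. This small exchange therefore gives the first direct reading at this place, and the data shown offer no measurement that bears on the result.

All four compounds still lie within the scatter of their neighbours, so nothing shown yet marks out a group on this ring that moves the number clearly in either direction. On these data alone, it remains open whether an amine, a carboxylic acid or a longer chain at this place would give a step beyond the scatter, and whether fluoro would read the same with 1,3-benzoxazol-2-yl in place of 1,3-benzothiazol-2-yl.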